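The compounds below may be only part of what the source reports. "The series", "measured", "known", "first", "only" and "open" are said of these compounds alone.

Compound 1 `CSc1nccc2c1ncn2C1O[C@H](CO)[C@@H](O)[C@H]1O` in a functional assay on EL4 cells (Mus musculus) for inhibition, tested at 100 uM (a lower number here means less inhibition, a higher number more inhibition at the concentration tested (going by the name of the read-out)), gives < 5%, which is a limit of the assay rather than a number. Compound 2 `CCNc1nccc2c1ncn2C1O[C@H](CO)[C@@H](O)[C@H]1O` in this assay gives 8%. Compound 3 `OC[C@H]1OC(n2cnc3c(S)nccc32)[C@H](O)[C@@H]1O` in this assay gives < 5%, again a limit of the assay and not a number.

Compound 3 thus stands at the limit of < 5% in this assay, at which 2 of the 3 values shown sit, so its inhibition is known only as a ceiling. Compound 4 `CN(C)c1nccc2c1ncn2C1O[C@H](CO)[C@@H](O)[C@H]1O` differs from compound 3 in one place: dimethylamino in place of sulfanyl on an aromatic carbon. Among the compounds with values here, two measured steps bear on this change, as both exchange a sulfur group and an amino group on an aromatic carbon of the shared core. One was a number at least 3 percentage points higher from compound 1 to compound 2 (that floor lies within the scatter). The other was a number at least 3 percentage points lower from compound 2 to compound 3 (that floor lies within the scatter). Neither step rose beyond the scatter, and the amino compound sat on the higher side each time, so an amino group in place of a sulfur group has so far moved inhibition in this assay only slightly, if at all. For compound 4 the expected step is therefore small and upward at most, a number at least 1 percentage points higher from compound 3 to compound 4 (that floor lies within the scatter), and the result may once more come out as a limit. Compound 4 is estimated at 6%, within 0% to 15%.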

Compound 4, a percentage reported as inhibition, at one concentration (the size of the read-out at that concentration, not a potency): 10%
For compound 4 the middle estimate is 4 percentage points below the measured one; the range from low to high includes it.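

Dimethylamino in place of ethylamino, on the aromatic carbon next to the ring nitrogen, gives no readable change in this assay, with a number 2 percentage points higher from compound 2 to compound 4 (within the scatter). Set against the sulfur groups, dimethylamino gives a number at least 5 percentage points higher from compound 3 to compound 4 (that floor lies within the scatter) and a number at least 5 percentage points higher from compound 1 to compound 4 (that floor lies within the scatter), floors larger than those of the earlier amino-for-sulfur steps, though still not beyond the scatter. The true size of these two steps stays unknown, as each starts from a limit of the assay rather than a number: the limit of < 5% in this assay, at which 2 of the 4 values shown sit.

On these data alone, whether any group at this position can raise inhibition beyond the scatter remains open. So does the effect of a plain amine, a longer chain such as butylamino, or a carboxylic acid on this carbon.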